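This account rests on a few compounds, and the source may have more. Where it says the series, first, only, none or still open, it means among the compounds named here.

Measured so far in an assay on isolated protein for agonist activity at prostaglandin E2 receptor EP2 subtype (Homo sapiens); on this read-out lower numbers stand for an effect already at smaller amounts and higher numbers for an effect only at larger amounts of compound:
Compound 1 `CCCCC(C)(C)[C@H](O)/C=C/[C@H]1CCC(=O)N1CCSc1nc(C(=O)O)cs1`: 0.91 nM
Compound 2 `O=C(O)c1csc(SCCN2C(=O)OC[C@@H]2/C=C/[C@@H](O)C2(CCc3ccccc3)CCC2)n1`: 160 nM
Compound 3 `COCCCC1([C@H](O)/C=C/[C@H]2COC(=O)N2CCSc2nc(C(=O)O)cs2)CCC1`: 18 nM

Compound 3 stands second highest of the three numbers in this assay; compound 2 sits nearest with the higher number, compound 1 furthest with the lower one. For the measured compounds named here, the one single-point step recorded so far is the change from compound 2 to compound 3, a methoxymethyl in place of phenyl on a saturated chain carbon, which gave an 8.9-fold lower number from compound 2 to compound 3 (0.95 log units; beyond the scatter).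

Compound 4 `CC#CCC1([C@H](O)/C=C/[C@H]2COC(=O)N2CCSc2nc(C(=O)O)cs2)CCC1` is the next case. It differs from compound 3 in this way: prop-1-yn-1-yl in place of 2-methoxyethyl on a saturated chain carbon bound to a saturated ring carbon. Going by the values given here, no measured step alters this substituent alone in the same manner; the only step at this part of the molecule is the one from compound 2 to compound 3, and it removes a ring rather than an ether. Compound 1, with an open-chain branched alkyl at the corresponding position and a different core, gives the lowest number, but its several differences cannot be separated. Without a bearing step, no shift beyond the scatter is expected, and the estimate for compound 4 is 15 nM in this assay, range 4 nM to 60 nM, which means an expected step of a 1.2-fold lower number from compound 3 to compound 4 (0.08 log units; within the scatter).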

Compound 4, half-maximal effective concentration: 21 nM
The estimate for compound 4 lay 1.4-fold (0.15 log units) below the measured number; the measured number falls inside the stated range.
By their numbers in this assay, from the lowest: compound 1; then compounds 3 and 4 (each within the scatter of the next); then compound 2.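

In this assay, the step of a 1.2-fold higher number from compound 3 to compound 4 (0.07 log units; within the scatter) does not separate prop-1-yn-1-yl from 2-methoxyethyl at this position on the saturated chain carbon bound to a saturated ring carbon. The ether oxygen of compound 3 is therefore not needed to keep the number in this range, since the all-carbon substituent of compound 4 stands within the scatter of it. The step of a 7.6-fold lower number from compound 2 to compound 4 (0.88 log units; beyond the scatter), read with an 8.9-fold lower number from compound 2 to compound 3 (0.95 log units; beyond the scatter), shows that the gap to compound 2 appears with both non-aromatic chains, so it is not tied to the ether alone. Going by these compounds, how an amine at the end of the 3-methoxypropyl chain or a longer chain with a triple bond would read in this assay stays open. The data shown offer no evidence on why the numbers fall this way.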